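A few compounds are considered here, and "the series" means these few. Any claim that something is new, unique, unknown or untested is made for them only; others in the source may bear on it.

Working notes on the sulfonamide series.

Within the data shown here, compound 3 `COc1cc(N)c(Cl)cc1C(=O)CCC1CCN(CCNS(=O)(=O)c2cc(Br)ccc2Br)CC1` is the only member with a reported number: in an assay on HEK293 cells for displacement of a labelled ligand from 5-hydroxytryptamine receptor 6 (Homo sapiens), with a stated time of 60 min, tested at 1 uM, in the presence of a further agent that is not named here (on this read-out lower numbers stand for a weaker effect and higher numbers for a stronger effect at the one concentration tested), compound 3 gives 52%. Compound 1 `COc1ccc(S(=O)(=O)N2CCC(CCC(=O)c3cc(Cl)c(N)cc3OC)CC2)cc1` is reported in this assay as "not active" (no number reported), with no number attached. Compound 2 `COc1ccc(S(=O)(=O)NCCCN2CCC(CCC(=O)c3cc(Cl)c(N)cc3OC)CC2)cc1` is likewise reported in this assay as "not active" (no number reported), again without a number. On the figures shown, compound 3 therefore stands alone as the one entry with a measured effect, and no step between two measured compounds is available to calibrate the next change.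

Compound 4 `COc1cc(N)c(Cl)cc1C(=O)CCC1CCN(CCNS(=O)(=O)c2ccc(N)c(Br)c2)CC1` differs from compound 3 only at the sulfonyl group: 4-amino-3-bromophenyl in place of 2,5-dibromophenyl on a sulfonyl sulfur. The change swaps one bromine for an amino group and moves the remaining bromine, while the rest of the molecule is unchanged. Nothing in the series shows how this kind of change affects this assay.

Because compound 3 gives 52% and the new group brings a donor and an acceptor where there were none, a modest downward step a number 12 percentage points lower from compound 3 to compound 4 (beyond the scatter) is expected, with wide uncertainty. Compound 4 is expected to give about 40% in this assay, within 15% to 68%.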

Compound 4, a percentage reported as inhibition, at one concentration (the size of the read-out at that concentration, not a potency): 85%
The estimate for compound 4 lay 45 percentage points below the measured number; measured number outside the range, above it.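

In this assay, among these compounds, the aryl group on the sulfonyl sulfur gives the first readable single change: 4-amino-3-bromophenyl in place of 2,5-dibromophenyl gives a number 33 percentage points higher from compound 3 to compound 4 (beyond the scatter) within a shared core. The size of this step shows that the readout at this position depends on which aryl group is attached, and that a bromine of the 2,5-dibromophenyl group can be exchanged without loss of the effect. No supporting measurement bears on the result, and the step cannot be divided between the amino group gained, the bromine lost and the bromine moved.

Still open, as far as these compounds go, is whether an aminophenyl group without bromine, a bromophenyl group without the amino group, or a hydroxyl group in place of the amino group would keep the higher number. Steps involving compound 1 and compound 2 cannot be read, as neither has a number and both differ from the others in more than one place.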